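From methoxy to ethoxy on a shared core

This account rests on a few compounds, and the source may have more. Where it says the series, first, only, none or still open, it means among the compounds named here.

Compound 1 `COc1ccc(-n2c(S)nnc2Sc2nnc(-c3ccccc3)n2-c2ccccc2)cc1`: "not determined" (no result reported)
Compound 2 `Fc1ccc(-n2c(S)nnc2CSc2nnc(-c3ccccc3)n2-c2ccccc2)cc1`: 16700 nM

In a functional assay on HT-29 cells (Homo sapiens) for inhibition, read by MTT assay, with a stated time of 48 h (a higher number here means a weaker inhibitor, a lower number a stronger inhibitor), compound 2 gives 16700 nM. For compound 1 no single number exists in this assay, so compound 1 cannot be placed on the scale. Compound 3 `CCOc1ccc(-n2c(S)nnc2Sc2nnc(-c3ccccc3)n2-c2ccccc2)cc1` differs from compound 1 by methyl in place of hydrogen on a saturated chain carbon bound to an oxygen on an aromatic ring. For the measured compounds named here, no step between measured compounds is available, so the change from compound 1 to compound 3 is expected to stay within the scatter of this assay, in no set direction. Going by the values given here, the only measured point is compound 2 at 16700 nM. Compound 3 is therefore estimated to give 20000 nM in this assay, between 5000 nM and 80000 nM.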

Compound 3, half-maximal inhibitory concentration: 46800 nM
Beside the measured number, compound 3's estimate is 2.3-fold (0.37 log units) below it, and the stated range covers the measured number.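

In this assay, for the compounds shown here, compound 1 stands as "not determined" (no result reported) while compound 3 gives 46800 nM and so no step between them can be read. The compounds shown leave open how methoxy to ethoxy shifts activity on the shared core. Nothing at hand bears on this result.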